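The source may report more compounds than this note shows. Statements on the series, on what has been measured and on what is new or still open speak of the compounds shown alone.

Measured so far in this series:
- compound 1 `COc1ccc(C)cc1-c1c(C)nn(-c2nc(-c3ccc(Cl)c(Cl)c3)c(SC(C)C)s2)c1C(=O)O`: 9500 nM
- compound 2 `COc1ccccc1-c1c(C)nn(-c2nc(-c3ccc(Cl)c(Cl)c3)c(SC(C)C)s2)c1C(=O)O`: 14700 nM
- compound 3 `COc1cc(C#N)cc(-c2c(C)nn(-c3nc(-c4ccc(Cl)c(Cl)c4)c(SC(C)C)s3)c2C(=O)O)c1`: 5200 nM

In a functional assay on BJAB cells (Homo sapiens) for antiproliferative activity, with a stated time of 4 days (a higher number here means that more compound is needed for the effect, a lower number that less compound is needed), compound 3 gives the lowest of the three numbers. Its nearest neighbour is compound 1, the step being a 1.8-fold lower number from compound 1 to compound 3 (0.26 log units; within the scatter); the furthest is compound 2, with a 2.8-fold lower number from compound 2 to compound 3 (0.45 log units; beyond the scatter). Between the other two the step is a 1.5-fold higher number from compound 1 to compound 2 (0.19 log units; within the scatter). All three measured changes sit on the same aryl group attached to the shared core, and none of them moves the number by more than a modest amount.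

Compound 4 `CNc1cc(-c2c(C)nn(-c3nc(-c4ccc(Cl)c(Cl)c4)c(SC(C)C)s3)c2C(=O)O)ccn1` is the next member. Its difference from compound 3: 2-(methylamino)pyridin-4-yl in place of 3-cyano-5-methoxyphenyl on an aromatic carbon. For the measured compounds named here, no measured step exchanges this aryl group for a six-membered ring with a hetero atom, so nothing bears on the change directly. The steps that come closest are a 1.8-fold lower number from compound 1 to compound 3 (0.26 log units; within the scatter) and a 2.8-fold lower number from compound 2 to compound 3 (0.45 log units; beyond the scatter), both changes of substituents on the same ring, and both small. The expectation for this assay is therefore no step beyond the scatter, in either direction, with wide uncertainty given the lack of a matching precedent.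

Compound 4 is estimated at 5000 nM, within a range of 1500 nM to 16000 nM, which corresponds to an expected step of a 1.0-fold lower number from compound 3 to compound 4 (0.02 log units; within the scatter).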

Compound 4, half-maximal effective concentration: 18000 nM
Compound 4: middle estimate off by 3.6-fold (0.56 log units), on the low side, outside the stated range (above it).
By their numbers in this assay, from the lowest: compounds 3, 1, 2 and 4 (each within the scatter of the next, the first and the last beyond it).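

In this assay, for the compounds shown here, 2-(methylamino)pyridin-4-yl is the first ring with a hetero atom at this position, and replacing 3-cyano-5-methoxyphenyl with it gives a 3.5-fold higher number from compound 3 to compound 4 (0.54 log units; beyond the scatter), so this position can register an aryl exchange beyond the scatter. The same ring does not separate from the two methoxyphenyl groups, with a 1.2-fold higher number from compound 2 to compound 4 (0.09 log units; within the scatter) and a 1.9-fold higher number from compound 1 to compound 4 (0.28 log units; within the scatter), which places compound 4 with compound 1 and compound 2 and leaves compound 3 apart from compound 4. No measured information on these compounds accounts for the step from 3-cyano-5-methoxyphenyl.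

From the compounds shown here alone, whether the higher number follows the ring nitrogen, the methylamino group or the loss of the nitrile stays open, as compound 4 changes all three together. A primary amine or a methoxy group in place of the methylamino group on the same pyridin-4-yl ring would help separate these contributions, and a nitrile on that ring would test whether the gain seen with compound 3 carries over.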